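Swapping the aryl group on a tetrabrominated benzotriazole series

The source may hold more compounds than are shown below. What is called first, only, known or untested is meant among the compounds shown, and "the series" means these compounds.

Compound 2 `COc1cccc(C(O)CCn2nc3c(Br)c(Br)c(Br)c(Br)c3n2)c1` carries the shared core with a 3-methoxyphenyl group on a saturated chain carbon bound to an oxygen on a saturated carbon and a saturated chain carbon. In a functional assay on MCF7 cells (Homo sapiens) for antiproliferative activity, read by MTT assay, with a stated time of 24 h, tested at 25 uM (a higher number here means a weaker effect of the compound at the concentration tested, a lower number a stronger effect), compound 2 gives 71%, the lowest of the two numbers measured. Its nearest neighbour is compound 1 `OC(CCn1nc2c(Br)c(Br)c(Br)c(Br)c2n1)c1ccc(F)cc1`, which in this assay gives 101%. Within the data shown here, the one measured step, a number 30 percentage points lower from compound 1 to compound 2 (beyond the scatter), shows that exchanging the 4-fluorophenyl group of compound 1 for the 3-methoxyphenyl group of compound 2 goes along with a stronger effect.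

Compound 3 `OC(CCn1nc2c(Br)c(Br)c(Br)c(Br)c2n1)c1ccc(Br)cc1` has not been measured. It differs from compound 2 in that (4-bromophenyl in place of 3-methoxyphenyl on a saturated chain carbon bound to an oxygen on a saturated carbon and a saturated chain carbon). This change brings back a ring bearing a single halogen substituent, as in compound 1, so the step from compound 1 to compound 2 is the only one that bears on it. That step was modest and went downward, so the reverse direction would be expected here. For compound 3 the estimate in this assay is 90%, with a likely range from 70% to 105%, which corresponds to an expected step of a number 19 percentage points higher from compound 2 to compound 3 (beyond the scatter).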

Compound 3, a percentage reported as activity, at one concentration (the size of the read-out at that concentration, not a potency): 59%
Estimate against measurement, compound 3: 31 percentage points above, outside the stated range (below it).
By their numbers in this assay, from the lowest: compound 3; then compound 2; then compound 1.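

The aryl group at this position responds to which halogen it carries, not merely to whether it carries one: in this assay, bromo in place of fluoro on the aromatic carbon goes with a number 42 percentage points lower from compound 1 to compound 3 (beyond the scatter) and is the largest step in the set. The 4-bromophenyl group also outdoes the 3-methoxyphenyl group, with a number 12 percentage points lower from compound 2 to compound 3 (beyond the scatter) as the step, so compound 3 has the strongest effect of the three, while compound 1, the other compound with a single halogen on its ring, has the weakest. Nothing available explains why these two halogens give such different results.

On these data alone, whether a 4-chlorophenyl group at the same place would fall between compound 1 and compound 3 remains open, as does whether any halogen at all is needed there, which a ring bearing an amine could help to test. The effect of the 3-methoxyphenyl group also cannot yet be divided between the methoxy group itself and where it sits on the ring, a question that a 4-methoxyphenyl group would address.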